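Extending the Methyl of Compound 1 with Dimethylamino

The compounds below may be only part of what the source reports. "The series", "measured", "known", "first", "only" and "open" are said of these compounds alone.

Compound 1 `Cc1cccc(Nc2nc(-c3ccncc3)c(C)s2)c1` is examined in a functional assay on RCC4 cells (Homo sapiens) for inhibition, read by XTT assay, with a stated time of 4 days (on this read-out higher numbers stand for weaker inhibition and lower numbers for stronger inhibition), where compound 1 gives 10000 nM. Of the two single numbers in this assay, this is the lower one; compound 3 `Oc1cccc(Nc2nc(-c3ccncc3)cs2)c1` gives 28800 nM, a gap beyond the usual scatter. Compound 2 `Cc1cccc(Nc2nc(-c3ccncc3-c3ccc(S(C)(=O)=O)cc3)cs2)c1` appears with several entries, (the several entries of compound 2 in this assay, 1600 nM; 1620 nM (2 entries)), and so has no single number. The change to compound 4 `Cc1cccc(Nc2nc(-c3ccncc3)c(CN(C)C)s2)c1` is dimethylamino in place of hydrogen on a saturated chain carbon bound to an aromatic carbon. Within the data shown here, no measured pair shows this change, so its size is open; a step in this assay within the scatter, or a modest move toward stronger inhibition, is expected, as compound 2 reaches 1600 nM; 1620 nM (2 entries) with a different enlargement of the shared core. In this assay compound 4 is expected to give 5000 nM, between 1500 nM and 20000 nM, a step of a 2.0-fold lower number from compound 1 to compound 4 (0.30 log units; within the scatter).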

Compound 4, half-maximal inhibitory concentration: 16200 nM
For compound 4 the middle estimate is 3.2-fold (0.51 log units) below the measured one; the range from low to high includes it.
By their numbers in this assay, from the lowest: compounds 1, 4 and 3 (each within the scatter of the next, the first and the last beyond it).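

In this assay, dimethylamino in place of hydrogen on a saturated chain carbon bound to an aromatic carbon gives a 1.6-fold higher number from compound 1 to compound 4 (0.21 log units; within the scatter). This first measured step at this position shows that going from methyl to (dimethylamino)methyl does not shift the read-out beyond the scatter. The data shown offer no explanation for this outcome. Going by these compounds, it remains open whether a primary amine, a carboxylic acid or a longer chain on this carbon would give a step beyond the scatter, and in which direction.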